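A Second Chloro in a Cytotoxicity Series

This account rests on a few compounds, and the source may have more. Where it says the series, first, only, none or still open, it means among the compounds named here.

Of the compounds shown here, three have so far been tested in an ADME assay on NIH3T3 cells (Mus musculus) for cytotoxicity, read by XTT assay, with a stated time of 24 h; on this read-out lower numbers stand for stronger inhibition and higher numbers for weaker inhibition. Compound 1 `Cn1nnnc1SCC(=O)N/N=C/c1ccccc1` gives 9700000 nM in this assay. Compound 2 `Cn1nnnc1SCC(=O)N/N=C/c1ccc(Cl)cc1` gives 2100000 nM, and compound 3 `C/C(=N\NC(=O)CSc1nnnn1C)c1ccc(Cl)cc1` gives 100000 nM. The change chloro in place of hydrogen on an aromatic carbon brings a 4.6-fold lower number from compound 1 to compound 2 (0.66 log units; beyond the scatter). The difference between the core of compound 1 and the core of compound 3 is not broken down here; the two values simply show compound 3 with the lowest number of the three.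

Compound 4 `C/C(=N\NC(=O)CSc1nnnn1C)c1ccc(Cl)cc1Cl` has not yet been measured. Going by the values given here, it differs from compound 3 by chloro in place of hydrogen on an aromatic carbon, the same kind of change as the one between compound 1 and compound 2, though not the same: in compound 2 the new chloro sits para to a large group, whereas in compound 4 it sits ortho to a large group and meta to a chloro group. Resting on a 4.6-fold lower number from compound 1 to compound 2 (0.66 log units; beyond the scatter), a somewhat smaller step, a 2.5-fold lower number from compound 3 to compound 4 (0.40 log units; beyond the scatter), is expected in this assay. The expected value for compound 4 in this assay is therefore 40000 nM, with a likely range from 10000 nM to 150000 nM.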

Compound 4, half-maximal inhibitory concentration: 1000000 nM
Compound 4: middle estimate off by 25-fold (1.40 log units), on the low side; measured number outside the range, above it.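

In this assay, the added chloro gives a 10-fold higher number from compound 3 to compound 4 (1.00 log units; beyond the scatter), so the number rises here, whereas the earlier chloro on the core of compound 1 lowered it. In this series, the same kind of change therefore does not carry over from one core to the other, in either direction or size: the same change on two cores in this assay, a 4.6-fold lower number (0.66 log units; beyond the scatter) from compound 1 to compound 2 and a 10-fold higher number (1.00 log units; beyond the scatter) from compound 3 to compound 4, 46-fold (1.66 log units) apart, beyond the scatter of two such steps What this does not show is the reason, for the two steps differ both in the core and in where the chloro sits, and in compound 4 it stands ortho to a large group and meta to a chloro group, so two steps alone cannot separate these factors.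

The compounds shown leave open whether a chloro at this same place on the core of compound 1 would also raise the number. They also leave open whether the rise is tied to chloro itself or would also appear with another group there, such as a methyl or a methoxy group.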